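Adding an amino group to compound 1

The source may hold more compounds than are shown below. What is called first, only, known or untested is meant among the compounds shown, and "the series" means these compounds.

Within the data shown here, in an ADME assay on microsomes from liver (Mus musculus) for pharmacokinetics, read by LC-MS, using NADPH, with stated times of 5 min, 15 min and 30 min, tested at 10 uM (on this read-out higher numbers stand for fast clearance and lower numbers for slow clearance), compound 1 `C[C@@H](c1ccc(NC(=O)N2CC(c3cccnc3)C2)cc1)N1Cc2ccccc2C1=O` gives 123 mL.min-1.g-1, the higher of the two numbers so far, and compound 2 `CCC(=O)N[C@@H](C)c1ccc(NC(=O)N2CC(c3cccnc3)C2)cc1` gives 31.4 mL.min-1.g-1. Compound 3 `C[C@@H](c1ccc(NC(=O)N2CC(c3ccc(N)nc3)C2)cc1)N1Cc2ccccc2C1=O` differs from compound 1 in one place: amino in place of hydrogen on an aromatic carbon. This takes pyridin-3-yl to 6-aminopyridin-3-yl, with amino in place of hydrogen on an aromatic carbon, next to the ring nitrogen. Among the measured compounds shown here, the only measured step, a 3.9-fold lower number from compound 1 to compound 2 (0.59 log units; beyond the scatter), is beyond the scatter but exchanges a different group and leaves the pyridin-3-yl group untouched. It shows that this assay can move within this series, yet no measurement bears directly on the new amino group. No change beyond the scatter is therefore expected, and the expected size is a 1.2-fold lower number from compound 1 to compound 3 (0.09 log units; within the scatter). For compound 3 the estimated clearance is 100 mL.min-1.g-1, with an expected range from 48 mL.min-1.g-1 to 200 mL.min-1.g-1.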

Compound 3, intrinsic clearance in microsomes: < 25 mL.min-1.g-1
Compound 3 gave a limit, no number; the forecaster's own chance of this, stated with the estimate: 3%; middle value at least 4.0-fold (0.60 log units) from the limit.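

Amino in place of hydrogen on an aromatic carbon, next to the ring nitrogen, gives an at least 4.9-fold lower number from compound 1 to compound 3 (0.69 log units; beyond the scatter) in this assay and shows that the pyridin-3-yl group, which the earlier step left untouched, is itself a place where this read-out moves. Compound 3 gave a limit and no number: the limit of < 25 mL.min-1.g-1 in this assay, at which 1 of the 3 values shown sits. As far as these compounds go, the full size of the step therefore stays unknown, but one added amino group, taking pyridin-3-yl to 6-aminopyridin-3-yl, is enough to carry the clearance beyond the scatter.

The compounds shown leave open whether the same change would act alike on compound 2, which carries a different group on the saturated chain carbon. They also leave open whether a hydroxyl, a methoxy or a dimethylamino group in this place would lower the number as the amino group does.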